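Working notes: ring methyl added to compound 1

The source may report more compounds than this note shows. Statements on the series, on what has been measured and on what is new or still open speak of the compounds shown alone.

Compound 1 `CCCCCCCCCCCCc1ccccc1C(SCCC(=O)O)SCCC(=O)O` gives the lowest number of the three measured in an assay on membranes from lung (Cavia porcellus) for binding affinity to cysteinyl leukotriene receptor (Homo sapiens) (a higher number here means a weaker inhibitor, a lower number a stronger inhibitor), at 445 nM. In this assay compound 2 `CCCCCCCCc1ccccc1C(SCCC(=O)O)SCCC(=O)O` gives 5670 nM, and compound 3 `CCCCc1ccc(CCCCc2ccccc2C(SCCC(=O)O)SCCC(=O)O)cc1` gives 4230 nM. In the step of a 13-fold higher number from compound 1 to compound 2 (1.11 log units; beyond the scatter) and in the step of a 9.5-fold higher number from compound 1 to compound 3 (0.98 log units; beyond the scatter) what differs is the saturated chain carried by the core of compound 1; the step of a 1.3-fold lower number from compound 2 to compound 3 (0.13 log units; within the scatter) stays within the scatter.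

Compound 4 `CCCCCCCCCCCCc1cccc(C)c1C(SCCC(=O)O)SCCC(=O)O` differs from compound 1 by methyl in place of hydrogen on an aromatic carbon. Neither of the steps that moved the number beyond the scatter touches the aromatic ring: both shortened or exchanged the chain. Among the measured compounds shown here, no measured step therefore bears directly on a substituent placed on the ring, and nothing among the measured compounds shows such a substituent moving the number in either direction. The expectation is that compound 4 stays near compound 1 in this assay, with a step of about a 1.0-fold higher number from compound 1 to compound 4 (0.00 log units; within the scatter) that is not expected to exceed the scatter. Compound 4 is estimated at 450 nM, with a range from 150 nM to 1400 nM reflecting the absence of any measured step on the ring.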

Compound 4, inhibition constant: 3670 nM
Compound 4: middle estimate off by 8.2-fold (0.91 log units), on the low side; measured number above the stated range.
By their numbers in this assay, from the lowest: compound 1; then compounds 4, 3 and 2 (each within the scatter of the next).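

In this assay, the aromatic ring of the shared core proves to be a sensitive place: methyl in place of hydrogen on an aromatic carbon, ortho to a large group and meta to a large group, gives an 8.2-fold higher number from compound 1 to compound 4 (0.92 log units; beyond the scatter). The earlier steps shown here beyond the scatter, a 13-fold higher number from compound 1 to compound 2 (1.11 log units; beyond the scatter) and a 9.5-fold higher number from compound 1 to compound 3 (0.98 log units; beyond the scatter), both concerned the saturated chain, and this step shows that a change of 1 heavy atom on the ring, with the chain left as it stands, also moves the number beyond the scatter. No measurement at hand accounts for this step, which therefore stands as an observation without an assigned cause.

Open, going by these compounds, is whether a fluorine atom or a methoxy group on this same aromatic carbon would move the number as methyl does, and whether methyl on another aromatic carbon of the ring would give a step of similar size. Also open, on these data alone, is whether the same ring methyl would raise the number on the shorter chain of compound 2 or on the butylphenyl-bearing chain of compound 3, as it does on the chain of compound 1.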